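Oxindole bromo removal in a pyrazoline-thiazolone series

The source may report more compounds than this note shows. Statements on the series, on what has been measured and on what is new or still open speak of the compounds shown alone.

Two compounds of the shared core have numbers in a functional assay on Mino cells (Homo sapiens) for cytotoxicity, read by MTT assay, with a stated time of 72 h; a lower number here means a stronger inhibitor, a higher number a weaker inhibitor. Compound 1 `O=C1N=C(N2N=C(c3ccc(Cl)cc3)CC2c2ccc(Cl)cc2)S/C1=C1\C(=O)Nc2ccccc21` gives 68200 nM in this assay, while compound 2 `O=C1N=C(N2N=C(c3ccc(Br)cc3)CC2c2ccc(Cl)cc2)S/C1=C1\C(=O)Nc2ccc(Br)cc21` gives 270 nM, the lower of the two numbers, with compound 1 standing far higher, beyond the scatter. Compound 1 and compound 2 differ in two places at once, so no single change can be read from that pair.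

Compound 3 `O=C1N=C(N2N=C(c3ccc(Br)cc3)CC2c2ccc(Cl)cc2)S/C1=C1\C(=O)Nc2ccccc21` is not yet measured. It differs from compound 2 by hydrogen in place of bromo on an aromatic carbon. The bromo that leaves sits on the same ring where compound 1 also carries hydrogen, and compound 1 is by far the weaker inhibitor, so the step is expected to go toward a higher number and to be larger than the scatter. The expected step from compound 2 to compound 3 is a 15-fold higher number from compound 2 to compound 3 (1.17 log units; beyond the scatter). Compound 3 is estimated at 4000 nM, in the range 600 nM to 30000 nM.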

Compound 3, half-maximal inhibitory concentration: 10000 nM
The estimate for compound 3 lay 2.5-fold (0.40 log units) below the measured number; measured number inside the range.
By their numbers in this assay, from the lowest: compound 2; then compound 3; then compound 1.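

In this assay the bromo on the aromatic carbon meta to a fused ring and para to a fused ring now has a reading of its own: a 37-fold higher number from compound 2 to compound 3 (1.57 log units; beyond the scatter) with hydrogen in place of bromo, a large step that shows this position is sensitive to the change. The bromo in place of chloro change on the other aromatic carbon is also resolved, at a 6.8-fold lower number from compound 1 to compound 3 (0.83 log units; beyond the scatter) in a modest step. Together the two single changes split the gap between compound 1 and compound 2, which could not be divided before, and both point the same way, with the larger share at the bromo that leaves.

Going by these compounds, it remains open whether chloro, methoxy or an amine on that aromatic carbon would match bromo. Nothing measured here bears on the cause of either step.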